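A phenyl for a propyl in compound 4

This account rests on a few compounds, and the source may have more. Where it says the series, first, only, none or still open, it means among the compounds named here.

In a functional assay on RAW264.7 cells (Mus musculus) for inhibition, read by Griess assay, with stated times of 1 h and 24 h (a higher number here means a weaker inhibitor, a lower number a stronger inhibitor), compound 1 `O=C1CC(c2ccccc2OCc2ccc(F)cc2)Oc2ccccc21` gives 28200 nM, compound 2 `CCCOc1ccccc1C1CC(=O)c2ccccc2O1` gives 46000 nM and compound 3 `CCCCOc1ccccc1C1CC(=O)c2ccccc2O1` gives 48700 nM. Compound 3 therefore stands level with the other two, since its value lies within the scatter of both.

Compound 4 `O=C1CC(c2ccccc2OCc2ccccc2)Oc2ccccc21` carries phenyl in place of propyl on a saturated chain carbon bound to an oxygen on an aromatic ring. Cut one bond further out, the same difference reads butoxy to benzyloxy.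

The most relevant evidence is a 1.7-fold higher number from compound 1 to compound 3 (0.24 log units; within the scatter), where propyl replaced 4-fluorophenyl at this same place. Replacing 4-fluorophenyl with ethyl gave a 1.6-fold higher number from compound 1 to compound 2 (0.21 log units; within the scatter), and lengthening the chain by a methyl gave a 1.1-fold higher number from compound 2 to compound 3 (0.02 log units; within the scatter). None of these steps goes beyond the scatter, so no change beyond the scatter is expected here either, in either direction.

The expected step is a 1.4-fold lower number from compound 3 to compound 4 (0.13 log units; within the scatter).

For compound 4 the estimated value is 36000 nM, with an expected range from 18000 nM to 70000 nM.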

Compound 4, half-maximal inhibitory concentration: 18900 nM
Compound 4: middle estimate off by 1.9-fold (0.28 log units), on the high side; the range from low to high includes it.
By their numbers in this assay, from the lowest: compounds 4, 1, 2 and 3 (each within the scatter of the next, the first and the last beyond it).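

Phenyl in place of propyl gives a 2.6-fold lower number from compound 3 to compound 4 (0.41 log units; beyond the scatter) and phenyl in place of ethyl gives a 2.4-fold lower number from compound 2 to compound 4 (0.39 log units; beyond the scatter) in this assay and these are the first steps at this place to pass beyond the scatter. The gain does not extend to every aromatic group: hydrogen in place of fluoro gives a 1.5-fold lower number from compound 1 to compound 4 (0.17 log units; within the scatter) and compound 1, with its 4-fluorophenyl, stays within the scatter of compounds 2 and 3, so it goes against any simple rule that an aromatic ring outdoes a chain here. Nothing available accounts for the difference between phenyl and these chains.

The compounds shown leave open whether an aromatic ring is needed at this place at all, which cyclohexyl in place of phenyl would test. They also leave open how a methoxy group or an amine on the phenyl ring would compare.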